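Adding a Nitro Group to Compound 1

A few compounds are considered here, and "the series" means these few. Any claim that something is new, unique, unknown or untested is made for them only; others in the source may bear on it.

- compound 1 (`O=C(CCCCC(S)CCS)Nc1ccccc1`) (5.49%)
- compound 2 (`O=C(CCCCC(S)CCS)Nc1ccccc1Cl`) ("not active" (no number reported))

For the measured compounds named here, in a functional assay on HO8910 cells (Homo sapiens) for inhibition, read by MTT assay, with a stated time of 24 h, tested at 10 ug/mL (a lower number here means less inhibition of growth, a higher number more inhibition of growth at the concentration tested), compound 1 gives (5.49%), the only number available, while compound 2 is reported as ("not active" (no number reported)) and has no number. Compound 3 (`O=C(CCCCC(S)CCS)Nc1ccc([N+](=O)[O-])cc1`) carries nitro in place of hydrogen on an aromatic carbon, para to a large group (nitro in place of hydrogen on an aromatic carbon). Going by the values given here, no measured step guides this change, so the expected step (a number 1.5 percentage points higher from compound 1 to compound 3 (within the scatter)) stays within the usual scatter, with no firm direction. Compound 3 is expected to give (7%), with an estimated range from (0%) to (20%).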

Compound 3, percent growth inhibition at one concentration: 8.96%
For compound 3 the middle estimate is 2 percentage points below the measured one; the measured number falls inside the stated range.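

In this assay, for the compounds shown here, nitro in place of hydrogen on an aromatic carbon, para to a large group, brings a number 3.5 percentage points higher from compound 1 to compound 3 (within the scatter), the first measured step on the shared core. It shows that this change at this position does not move the reading beyond the scatter. No measurement available here bears on the reason for this result. The compounds shown leave open whether an amine or a carboxylic acid at this same position would shift the reading beyond the scatter.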